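Cytotoxicity on Dog Kidney Cells: Expectation for Compound 4

This account rests on a few compounds, and the source may have more. Where it says the series, first, only, none or still open, it means among the compounds named here.

The measured compounds, all tested in a toxicity assay on MDCK cells (Canis lupus familiaris) for cytotoxicity, read by crystal violet staining, with a stated time of 48 h; a lower number here means that less compound is tolerated, a higher number that more compound is tolerated:
Compound 1, `Cc1ccc2[nH]c(=O)c(CN(Cc3ccc(F)cc3)Cc3ccc(C(C)(C)C)cc3)cc2c1`, gives > 27000 nM, which is a limit of the assay rather than a number.
Compound 2, `Cc1ccc2[nH]c(=O)c(CN(Cc3ccc(F)cc3)Cc3ccc(-c4ccccc4)cc3)cc2c1`, gives > 5000 nM, again a limit.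
Compound 3, `Cc1ccc2[nH]c(=O)c(CN(Cc3ccc(F)cc3)Cc3cccc4ccccc34)cc2c1`, gives > 5000 nM, also a limit.

Compound 1 therefore stands only at a limit in this assay, at the limit of > 27000 nM in this assay, at which 1 of the 3 values shown sits, while the two other compounds sit at the limit of > 5000 nM in this assay, at which 2 of the 3 values shown sit. The step that the two limits leave unreadable from compound 1 to compound 2 and the step that the two limits leave unreadable from compound 1 to compound 3 are both unreadable, since the two limits differ and neither side is a number; nothing in these three results shows a cytotoxic concentration being reached.

Compound 4, `Cc1ccc2[nH]c(=O)c(CN(Cc3ccc(C(C)(C)C)cc3)[C@H](CO)c3ccccc3)cc2c1`, is not yet measured. It differs from compound 1 in that (2-hydroxy-1-phenylethyl in place of 4-fluorobenzyl on an amine nitrogen). Among the measured compounds shown here, no measured step bears directly on this change, and the two steps that exist give no readable size. With all three values at a limit, compound 4 is expected to behave alike, and a step of an at least 1.0-fold lower number from compound 1 to compound 4 (0.03 log units; that floor lies within the scatter) is estimated, which means no change beyond the scatter. Compound 4 is therefore expected to give about 25000 nM in this assay, within 6000 nM to 60000 nM, most probably reported as a limit.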

Compound 4, half-maximal cytotoxic concentration: > 10000 nM
Compound 4 gave a limit, no number; the forecaster's own chance of this, stated with the estimate: 75%; the middle value is on the limit's open side.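

In this assay compound 4 gives > 10000 nM, which is a limit and not a number. Among the compounds shown here, compound 1 also stands only at a limit, so no step from compound 1 to compound 4 can be read. The compounds shown leave open at what concentration any of them becomes cytotoxic, and whether 2-hydroxy-1-phenylethyl in place of 4-fluorobenzyl shifts that concentration at all.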